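Compound 4: 6-chloropyridin-3-yl replaces 2,6-dimethoxyphenyl

This account rests on a few compounds, and the source may have more. Where it says the series, first, only, none or still open, it means among the compounds named here.

Measured in a functional assay on PC-3 cells (Homo sapiens) for cytotoxicity, read by MTT assay, with a stated time of 48 h; on this read-out lower numbers stand for stronger inhibition and higher numbers for weaker inhibition:
- Compound 1 `CC1(C)CCC[C@]2(C)[C@@H](CC[C@@](C)(O)/C=C/c3cccc([N+](=O)[O-])c3)[C@](C)(O)CC[C@@H]12` gives 153 nM
- Compound 2 `CC1(C)CCC[C@]2(C)[C@@H](CC[C@@](C)(O)/C=C/c3cncc4ccccc34)[C@](C)(O)CC[C@@H]12` gives 3900 nM
- Compound 3 `COc1cccc(OC)c1/C=C/[C@](C)(O)CC[C@@H]1[C@@]2(C)CCCC(C)(C)[C@@H]2CC[C@@]1(C)O` gives 4000 nM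

Compound 3 stands at the weak end of this small set, level with compound 2. The step of a 1.0-fold higher number from compound 2 to compound 3 (0.01 log units; within the scatter) lies within the scatter, while the step of a 26-fold higher number from compound 1 to compound 3 (1.42 log units; beyond the scatter) is large. The next structure is compound 4 `CC1(C)CCC[C@]2(C)[C@@H](CC[C@@](C)(O)/C=C/c3ccc(Cl)nc3)[C@](C)(O)CC[C@@H]12` and it keeps the shared core and chain. For the measured compounds named here, its one change is this: 6-chloropyridin-3-yl in place of 2,6-dimethoxyphenyl on a double-bonded chain carbon bound to a double-bonded chain carbon.

All three measured steps bear on this change, since each is an exchange at the same place. The step of a 25-fold higher number from compound 1 to compound 2 (1.41 log units; beyond the scatter) is also large, so a swap here can move the number a long way. Yet only compound 1 reaches the low end, and the two other groups land together. Going by the values given here, none of the measured compounds carries 6-chloropyridin-3-yl, so the data offer no direct guide. A moderate move to a lower number in this assay is therefore expected, with a position between the two measured levels and considerable uncertainty. The expected step is a 2.7-fold lower number from compound 3 to compound 4 (0.43 log units; beyond the scatter). For compound 4 the estimated value is 1500 nM, with an expected range of 300 nM to 6000 nM.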

Compound 4, half-maximal inhibitory concentration: 275 nM
Compound 4: the middle estimate sits 5.5-fold (0.74 log units) above what was measured, and the stated range ends above it.
By their numbers in this assay, from the lowest: compounds 1 and 4 (each within the scatter of the next); then compounds 2 and 3 (each within the scatter of the next).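

In this assay, this position now shows a second group at the low level, since the change gives a 15-fold lower number from compound 3 to compound 4 (1.16 log units; beyond the scatter) and, set against the fused isoquinolin-4-yl, a 14-fold lower number from compound 2 to compound 4 (1.15 log units; beyond the scatter). The low level is therefore not tied to 3-nitrophenyl alone, for the exchange of that group for 6-chloropyridin-3-yl gives a 1.8-fold higher number from compound 1 to compound 4 (0.25 log units; within the scatter), and so two quite different groups on a double-bonded chain carbon bound to a double-bonded chain carbon stand together, apart from compound 2 and compound 3. No measurement is at hand that explains why these groups separate in this way.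

Going by these compounds, what remains open is whether the chlorine or the ring nitrogen of 6-chloropyridin-3-yl accounts for the step from the 2,6-dimethoxyphenyl compound, and a plain pyridin-3-yl or a 3-chlorophenyl group at the same place would pull the two apart. On these data alone, it is equally open whether the chlorine itself can be exchanged, as with a 6-aminopyridin-3-yl or a 6-methoxypyridin-3-yl group, without leaving the low level seen for compound 1 and compound 4.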